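A piperidine in place of a piperazinone on the shared core

The source may report more compounds than this note shows. Statements on the series, on what has been measured and on what is new or still open speak of the compounds shown alone.

Among the measured compounds shown here, compound 2 `CN1CCN(c2ccc3c(c2)oc(=O)n3C(=O)NCCCCc2ccccc2)CC1=O` gives 0.5 h in an ADME assay on microsomes from liver (Mus musculus) for metabolic stability, read by LC-MS, using NADPH, with stated times of 15 min and 60 min, tested at 4.6 uM (on this read-out lower numbers stand for a shorter-lived compound and higher numbers for a longer-lived compound), and is the only compound with a numbered value there. Compound 1 `CC(C)CNC(=O)n1c(=O)oc2cc(C3CCN(C)CC3)ccc21` reaches the limit > 1 h in this assay, a limit of the assay rather than a number, as the limit of > 1 h in this assay, at which 1 of the 2 values shown sits, records. Compound 3 `CC(C)CN1CCC(c2ccc3c(c2)oc(=O)n3C(=O)NCCCCc2ccccc2)CC1` differs from compound 2 by 1-isobutylpiperidin-4-yl in place of 4-methyl-3-oxopiperazin-1-yl on an aromatic carbon. No measured step covers this change, so its direction cannot be read from the data shown. Compound 3 is expected to give 0.6 h in this assay, with a range from 0.3 h to 1.2 h. The implied step a 1.2-fold higher number from compound 2 to compound 3 (0.08 log units; within the scatter) is expected to stay within the usual scatter.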

Compound 3, half-life: 1 h
For compound 3 the middle estimate is 1.7-fold (0.22 log units) below the measured one; the range from low to high includes it.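

In this assay, among the compounds shown here, the first measured step at this position, 1-isobutylpiperidin-4-yl in place of 4-methyl-3-oxopiperazin-1-yl on an aromatic carbon, gives a 2.0-fold higher number from compound 2 to compound 3 (0.30 log units; within the scatter). The half-life therefore does not separate these two six-membered rings, although they differ in ring hetero atoms and in the carbonyl. Compound 1 alone carries a limit of the assay rather than a number: the limit of > 1 h in this assay, at which 1 of the 3 values shown sits.

The compounds shown leave open whether a morpholine or an open-chain amine on this aromatic carbon would give a step beyond the scatter.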